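Adding a Nitro Group: What Compound 4 Might Show

The source may hold more compounds than are shown below. What is called first, only, known or untested is meant among the compounds shown, and "the series" means these compounds.

Three compounds sharing one core were tested in a functional assay on cells for positive allosteric modulation of metabotropic glutamate receptor 5 (Rattus norvegicus), read by calcium flux; on this read-out lower numbers stand for an effect already at smaller amounts and higher numbers for an effect only at larger amounts of compound. Compound 1 `O=C(Nc1cc(-c2ccccc2)nn1-c1ccccc1F)c1ccccc1` gives 104 nM, compound 3 `N#Cc1cccc(-n2nc(-c3ccccc3)cc2NC(=O)c2ccccc2)c1` gives 117 nM, and compound 2 `O=C(Nc1cc(-c2ccccc2)nn1-c1ccccc1Br)c1ccccc1` gives 200 nM, the largest of the three numbers, although a 1.9-fold higher number from compound 1 to compound 2 (0.28 log units; within the scatter) and a 1.7-fold lower number from compound 2 to compound 3 (0.23 log units; within the scatter) both sit within the scatter. Compound 4 `O=C(Nc1cc(-c2ccccc2)nn1-c1ccccc1Br)c1cccc([N+](=O)[O-])c1` differs from compound 2 by nitro in place of hydrogen on an aromatic carbon. The measured steps all change the aryl group on the aromatic nitrogen and leave the phenyl that receives the nitro untouched, so none of them bears directly on this change. For the measured compounds named here, with no relevant step in hand, the expectation for compound 4 is a step of no change at the digits printed from compound 2 to compound 4 (within the scatter) in this assay that stays within the scatter. Compound 4 is therefore estimated at 200 nM, with a range from 60 nM to 700 nM.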

Compound 4, half-maximal effective concentration: 68 nM
Compound 4: the middle estimate sits 2.9-fold (0.47 log units) above what was measured; the range from low to high includes it.
By their numbers in this assay, from the lowest: compounds 4, 1, 3 and 2 (each within the scatter of the next, the first and the last beyond it).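

For the compounds shown here, changing phenyl to 3-nitrophenyl gives a 2.9-fold lower number from compound 2 to compound 4 (0.47 log units; beyond the scatter) in this assay, the only step so far that lies beyond the scatter. Going by these compounds alone, this phenyl, left untouched by the earlier steps, is therefore a place where a single change can move the number, here towards an effect at smaller amounts of compound. Nothing available explains this step. The compounds shown leave open whether an amine or a carboxylic acid in the same place would move the number as nitro does, and whether nitro would give a similar step on compound 1 or compound 3.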